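The compounds below may be only part of what the source reports. "The series", "measured", "known", "first", "only" and "open" are said of these compounds alone.

Three compounds share one core and differ only in the group carried on one aromatic ring. Compound 1 `O=C(/C=C/c1ccc(C(F)(F)F)cc1)c1ccccc1O` gives 85.1% in a functional assay on HCT-116 cells (Homo sapiens) for cytotoxicity, read by MTT assay, with a stated time of 48 h, tested at 15 uM; on this read-out higher numbers stand for a weaker effect at the one concentration tested and lower numbers for a stronger effect. Compound 3 `COc1cccc(/C=C/C(=O)c2ccccc2O)c1O` gives 84.7% in this assay. Compound 2 `O=C(/C=C/c1cccc(Br)c1)c1ccccc1O` gives 29.6% in this assay, the lowest of the three numbers and so the strongest effect, as its gaps to compound 1 and to compound 3 both lie beyond the usual scatter. Compound 4 `Cc1cccc(/C=C/C(=O)c2ccccc2O)c1` is not yet measured; it differs from compound 2 by methyl in place of bromo on an aromatic carbon. Going by the values given here, no measured pair shows this change, so there is no direct guide. Because only compound 2 with its 29.6% shows a strong effect, a step upward, toward a weaker effect, is expected from a number 30.4 percentage points higher from compound 2 to compound 4 (beyond the scatter). Compound 4 is expected to give 60% in this assay, between 30% and 90%.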

Compound 4, a percentage reported as activity, at one concentration (the size of the read-out at that concentration, not a potency): 85.9%
For compound 4 the middle estimate is 25.9 percentage points below the measured one, within the range that was stated.
By their numbers in this assay, from the lowest: compound 2; then compounds 3, 1 and 4 (each within the scatter of the next).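

In this assay, going by these compounds alone, methyl in place of bromo gives a number 56.3 percentage points higher from compound 2 to compound 4 (beyond the scatter) and this pair is the first direct test of a single change at this position. The strong effect of compound 2 therefore depends on which group sits on this aromatic carbon, even though bromo and methyl each count one heavy atom. Nothing available here explains why the two groups differ so much.

Going by these compounds, whether chloro, an amine or a carboxylic acid on this carbon would keep the effect of compound 2 remains open. On these data alone, it is also open whether bromo would keep that effect on another carbon of the ring.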